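The compounds below may be only part of what the source reports. "The series", "measured", "known", "first", "only" and "open" are said of these compounds alone.

Series notes. Compound 1 `Nc1nc(NCCCCc2ccccc2)nc(-c2ccccc2CO)n1` gives 5.52 in a functional assay on cells for positive allosteric modulation of G-protein coupled receptor 68 (Homo sapiens), read by a luciferase reporter and cAMP accumulation, with a stated time of 30 min, at pH 6.8 and pH 8.3, in the presence of a further agent that is not named here; a lower number here means a less potent compound, a higher number a more potent compound, by a factor of ten per unit of this negative logarithm. Compound 2 `Nc1nc(NCCCCc2ccc(Oc3ccccc3)cc2)nc(-c2ccccc2CO)n1` carries a phenoxy in place of hydrogen on an aromatic carbon, and in this assay compound 2 gives 4.81; the change phenoxy in place of hydrogen on an aromatic carbon made the step of a number 0.71 log units lower from compound 1 to compound 2 (beyond the scatter). Compound 3 `Nc1nc(NCCCc2ccccc2)nc(-c2c(F)cccc2CO)n1` gives 4.47 in this assay, the lowest number of the three; how the core of compound 3 differs from the core of compound 1 is not broken down here. Compound 4 `Nc1nc(NCCCc2ccc(Oc3ccccc3)cc2)nc(-c2c(F)cccc2CO)n1` is not yet measured; it carries the same change as compound 2, (phenoxy in place of hydrogen on an aromatic carbon), at a place described in the same words. Among the compounds with values here, since the one earlier instance of this change, the step from compound 1 to compound 2, went down beyond the scatter, a step of about a number 0.67 log units lower from compound 3 to compound 4 (beyond the scatter) is expected for compound 4 in this assay. For compound 4 an estimate of 3.8, between 3.3 and 4.4, is therefore expected.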

Compound 4, negative logarithm of the antagonist equilibrium constant: 4.94
Estimate against measurement, compound 4: 1.14 log units below; the whole stated range lies below it.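

The change of phenoxy in place of hydrogen on an aromatic carbon does not carry over from one core to the other as a fixed step in this assay: the same change on two cores in this assay, a number 0.71 log units lower (beyond the scatter) from compound 1 to compound 2 and a number 0.47 log units higher (beyond the scatter) from compound 3 to compound 4, 1.18 log units apart, beyond the scatter of two such steps. On the core of compound 3 the change gives a number 0.47 log units higher from compound 3 to compound 4 (beyond the scatter), so a step read on one of these cores does not predict even the direction on the other. Within the data shown here, with only two pairs, this does not show which difference between the two cores goes with the reversal, nor how the change behaves on any further core.

On these data alone, it remains open which way the step would run on a third core. Also open, as far as these compounds go, is how a smaller ether such as methoxy, or a carboxylic acid, would compare at the same place on each core.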